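The source may report more compounds than this note shows. Statements on the series, on what has been measured and on what is new or still open speak of the compounds shown alone.

Measured compounds:
Compound 1 `Cc1cccc(C)c1-c1cccc(COc2ccc(CC3SC(=O)NC3=O)s2)c1` — in a functional assay on cells for agonist activity at Free fatty acid receptor 1 (Homo sapiens), read by calcium flux (on this read-out lower numbers stand for smaller maximal responses and higher numbers for larger maximal responses), compound 1 is given as "not determined" (no result reported).
Compound 2 `Cc1cccc(C)c1-c1cccc(OCc2cn(CCC(=O)O)nn2)c1` — 79.9%.

Compound 1 stands on no number at all: in this assay it was not determined, so nothing can be said of its own maximal response. Compound 2, in this assay, reaches 79.9%. Compound 3 `CCO[C@H](CC(=O)O)c1ccc(OCc2cccc(-c3c(C)cccc3C)c2)s1` is the compound still to be measured. It differs from compound 1 in one place: 2-carboxy-1-ethoxyethyl in place of (2,4-dioxo-1,3-thiazolidin-5-yl)methyl on an aromatic carbon. Going by the values given here, no step between two measured compounds is available, and compound 1 itself has no value, so there is no measured pair from which to read the size or direction of this change. The expectation therefore rests on compound 2 alone, which carries a carboxylic acid and reaches 79.9% in this assay, while compound 3 also carries a carboxylic acid. On that footing compound 3 is expected to give roughly 92% in this assay, within a range from 68% to 118%.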

Compound 3, largest response reached (Emax), in percent of the reference or control that the assay uses: 147%
Beside the measured number, compound 3's estimate is 55 percentage points below it; measured number outside the range, above it.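

No step can be read from this result, since compound 1 has no number in this assay and compound 3 therefore has nothing to be compared with. On these data alone, what replacing (2,4-dioxo-1,3-thiazolidin-5-yl)methyl with 2-carboxy-1-ethoxyethyl does to the maximal response stays open. No supporting data bear on this result.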